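A few compounds are considered here, and "the series" means these few. Any claim that something is new, unique, unknown or untested is made for them only; others in the source may bear on it.

Measured so far in a functional assay on L1210 cells (Mus musculus) for cytotoxicity, read by MTT assay, with a stated time of 24 h; a higher number here means a weaker inhibitor, a lower number a stronger inhibitor:
- compound 1 `COc1cc(C(=O)/C=C/c2ccc(Cl)cc2)cc(OC)c1OC`: 44500 nM
- compound 2 `COc1cc(C(=O)/C=C/c2ccc(C)cc2)cc(OC)c1OC`: 50500 nM
- compound 3 `COc1cc(C(=O)/C=C/c2c(Cl)cccc2Cl)cc(OC)c1OC`: 50500 nM

Compound 2 stands level with compound 3, and compound 1 lies within the scatter of both. The next change leads to compound 4 `COc1cc(C(=O)/C=C/c2ccc([N+](=O)[O-])cc2)cc(OC)c1OC`, with nitro in place of methyl on an aromatic carbon.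

The closest measured precedent is the exchange at this same place, methyl in place of chloro, which gave a 1.1-fold higher number from compound 1 to compound 2 (0.05 log units; within the scatter). The changes to the 2,6-dichlorophenyl group gave a 1.1-fold higher number from compound 1 to compound 3 (0.05 log units; within the scatter) and no change at the digits printed from compound 2 to compound 3 (within the scatter). Going by the values given here, no measured compound carries a nitro group, so these steps offer only indirect guidance. With all three within the scatter, no step beyond the scatter is expected in this assay. The estimated step is a 1.3-fold lower number from compound 2 to compound 4 (0.10 log units; within the scatter), with a slight allowance for the untested group. The estimate for compound 4 is 40000 nM, with an expected range of 18000 nM to 80000 nM.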

Compound 4, half-maximal inhibitory concentration: > 100000 nM
Compound 4: a limit, no number; the forecaster's own chance of this, stated with the estimate: 5%; at least 2.5-fold (0.39 log units) between middle value and limit.
By their numbers in this assay, from the lowest: compounds 1, 2 and 3 (each within the scatter of the next). At a limit, above all of these: compound 4.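

In this assay compound 4 gives > 100000 nM as a limit of the assay, not a number. Nitro in place of chloro on this aromatic carbon gives the first step in the series that clears the scatter (an at least 2.2-fold higher number from compound 1 to compound 4 (0.35 log units; beyond the scatter)), whereas the floor of the step from methyl stays inside it (an at least 1.9-fold higher number from compound 2 to compound 4 (0.29 log units; that floor lies within the scatter)). Compound 1 and compound 2 gave no sign that this aromatic carbon responds to its group, so the separation of compound 4 from compound 1 is new, though its true size stays hidden behind the limit.

On these data alone, it remains open whether this shift toward weaker inhibition belongs to nitro alone or extends to other groups on this aromatic carbon, such as an amine or a carboxylic acid. Ranking such groups against nitro would need readings that fall inside the range of the assay.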